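The source may report more compounds than this note shows. Statements on the series, on what has been measured and on what is new or still open speak of the compounds shown alone.

Measured compounds:
- compound 1, `C[C@@H](O)[C@H]1C(=O)N2C(C(=O)OCc3oc(=O)oc3C(C)(C)C)=C(S[C@@H]3CN[C@H](C(=O)Nc4cccc(C(=O)OCc5oc(=O)oc5C(C)(C)C)c4)C3)[C@H](C)[C@H]12`, > 95%
- compound 2, `CCC(CC)C(=O)OCOC(=O)C1=C(S[C@@H]2CN[C@H](C(=O)Nc3cccc(C(=O)O)c3)C2)[C@H](C)[C@@H]2[C@@H]([C@@H](C)O)C(=O)N12`, > 95%
- compound 3, `C[C@@H](O)[C@H]1C(=O)N2C(C(=O)OCOC(=O)OC(C)(C)C)=C(S[C@@H]3CN[C@H](C(=O)Nc4cccc(C(=O)OCOC(=O)OC(C)(C)C)c4)C3)[C@H](C)[C@H]12`, > 95%

All three read-outs come from a physicochemical assay for metabolic stability, read by LC-MS, in phosphate buffer, with a stated time of 3 h, at pH 7.4, tested at 50 uM; on this read-out lower numbers stand for a less stable compound and higher numbers for a more stable compound. For compound 2 the value > 95% is a limit of the assay and not a number. The same holds for compound 1, whose > 95% is a limit. Compound 3 likewise sits at a limit with > 95%. The three values therefore give no ranking among them; what they share is stated in the limit of > 95% in this assay, at which 3 of the 3 values shown sit. For the measured compounds named here, no pair of measured compounds differs in one place, so no measured step is available to calibrate the change toward compound 4.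

Compound 4, `C[C@@H](O)[C@H]1C(=O)N2C(C(=O)OCC(F)(F)F)=C(S[C@@H]3CN[C@H](C(=O)Nc4cccc(C(=O)O)c4)C3)[C@H](C)[C@H]12`, has not been measured in this assay. It is reached from compound 2 by trifluoromethyl in place of ((pentan-3-yl)carbonyl)oxy on a saturated chain carbon bound to an oxygen next to a carbonyl group. With compound 2 at a limit and every measured compound at the same limit, the expected step in this assay from compound 2 to compound 4 is a number at least 3 percentage points lower from compound 2 to compound 4 (that floor lies within the scatter), that is none beyond the scatter, with the caveat that a value resting on a limit can only move downward if it moves at all. Compound 4 is expected to give 92% in this assay, within 78% to 98%.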

Compound 4, percent of the compound remaining: > 95%
Compound 4 ended at the assay's limit (the forecaster's own chance of this, stated with the estimate: 55%); at least 3 percentage points between middle value and limit.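

No new step can be read between compound 2 and compound 4, since both stand at a limit of the assay and not at a number. The compounds shown leave open whether trifluoromethyl in place of ((pentan-3-yl)carbonyl)oxy changes the read-out of this assay at all, and they give no ranking within the series: the limit of > 95% in this assay, at which 4 of the 4 values shown sit.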